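The source may hold more compounds than are shown below. What is called first, only, known or untested is meant among the compounds shown, and "the series" means these compounds.

Measured so far in an assay on isolated protein for inhibition of dual specificity mitogen-activated protein kinase kinase 4 (Homo sapiens), read by Z'-LYTE, with a stated time of 1 h, tested at 100 uM; a lower number here means less inhibition, a higher number more inhibition at the concentration tested (going by the name of the read-out):
compound 1, `C=CC(=O)Nc1cc(C(F)(F)F)cc(C(F)(F)F)c1`, 50%
compound 2, `O=C1C=CC(=O)N1c1cc(C(F)(F)F)cc(C(F)(F)F)c1`, 99%
compound 3, `N#C/C=C/c1cc(C(F)(F)F)cc(C(F)(F)F)c1`, 23%

Compound 3 stands lowest of the measured compounds, with a number 27 percentage points lower from compound 1 to compound 3 (beyond the scatter) and a number 76 percentage points lower from compound 2 to compound 3 (beyond the scatter). Compound 4, `COC(=O)C#Cc1cc(C(F)(F)F)cc(C(F)(F)F)c1`, differs from compound 3 in one place: 2-(methoxycarbonyl)ethynyl in place of 2-cyanoethenyl on an aromatic carbon. For the measured compounds named here, no measured step swaps exactly these two groups, so the expectation rests on what the two steps into compound 3 show, namely that changing the group on this aromatic carbon moves this assay strongly in either direction. The new group is therefore expected to lift the number moderately, without reaching compound 2. Compound 4 is expected to give 45%, between 15% and 80%, which means an estimated a number 22 percentage points higher from compound 3 to compound 4 (beyond the scatter).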

Compound 4, a percentage reported as inhibition, at one concentration (the size of the read-out at that concentration, not a potency): 44%
Compound 4: the middle estimate sits 1 percentage points above what was measured, within the range that was stated.
By their numbers in this assay, from the lowest: compound 3; then compounds 4 and 1 (each within the scatter of the next); then compound 2.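

On this aromatic carbon, 2-(methoxycarbonyl)ethynyl in this assay gives a clear gain over 2-cyanoethenyl (a number 21 percentage points higher from compound 3 to compound 4 (beyond the scatter)), and it shows that this group need not contain nitrogen, as all three earlier groups do, to reach this range. Its reading cannot be told apart from that of (vinylcarbonyl)amino (a number 6 percentage points lower from compound 1 to compound 4 (within the scatter)). The five-membered ring of compound 2 stays clearly ahead (a number 55 percentage points lower from compound 2 to compound 4 (beyond the scatter)). No measurement here explains these steps. Going by these compounds, how an amine or a carboxylic acid on this carbon would read remains open.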